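Swapping fluoro for ethoxy: what dose to expect

A few compounds are considered here, and "the series" means these few. Any claim that something is new, unique, unknown or untested is made for them only; others in the source may bear on it.

Compound 1 `O=C(O)c1cnc2c(F)cccc2c1` gives 150 mg/kg in a functional assay on the whole organism (strain Sprague-Dawley) for inhibition, with Rattus norvegicus as the target; a lower number here means that less compound is needed, a higher number that more compound is needed for the effect.
Compound 2 `O=C(O)c1cnc2cc(C(F)(F)F)ccc2c1` gives > 25 mg/kg in this assay, which is a limit of the assay rather than a number.
Compound 3 `c1nc2ccc(C3CCCCC3)cc2cc1-c1nn[nH]n1` gives > 25 mg/kg in this assay, again a limit and not a number.

Among the three measured compounds, compound 1 therefore holds the only actual number; the other two results sit at the limit of > 25 mg/kg in this assay, at which 2 of the 3 values shown sit. For the measured compounds named here, no two of the measured compounds differ from one another in a single place, so no measured step is available to show how a change at one position shifts the dose.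

Compound 4 `CCOc1cccc2cc(C(=O)O)cnc12` differs from compound 1 as follows: ethoxy in place of fluoro on an aromatic carbon. Going by the values given here, with no measured step to rest on, the expectation for this assay is a shift of modest size, in either direction, or none beyond the usual scatter. For compound 4 the estimated minimum effective dose is 100 mg/kg, with a range from 30 mg/kg to 300 mg/kg. That estimate implies an expected step of a 1.5-fold lower number from compound 1 to compound 4 (0.18 log units; within the scatter).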

Compound 4, minimum effective dose: > 50 mg/kg
Compound 4 gave a limit, no number; the forecaster's own chance of this, stated with the estimate: 30%; the middle value does not contradict the limit.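

In this assay compound 4 gives > 50 mg/kg, which is a limit and not a number, so the step from compound 1 to compound 4 cannot be read. The compounds shown leave open whether ethoxy in place of fluoro on an aromatic carbon changes the dose needed, and in which direction.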